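From Fluoro to Trifluoromethyl: Expected Shift in Lipophilicity

The compounds below may be only part of what the source reports. "The series", "measured", "known", "first", "only" and "open" are said of these compounds alone.

Compound 2, `Cc1c(CN2CCCC2)cc(-c2ccc(F)cc2)n1Nc1ccnc2cc(Cl)ccc12`, and compound 1, `Cc1c(CN2CCCC2)cc(-c2ccc(Cl)cc2)n1Nc1ccnc2cc(Cl)ccc12`, share a common core and differ only in one group on an aromatic carbon. In a physicochemical assay for lipophilicity, at pH 5.2 (a higher number here means a more lipophilic compound, a lower number a more polar compound), compound 2 gives 3.45, while compound 1 gives 4.06. Going by the values given here, compound 2 therefore stands as the lower of the two numbers measured so far, and its nearest neighbour is compound 1. Among the compounds with values here, the single measured step, a number 0.61 log units lower from compound 1 to compound 2 (beyond the scatter), is the only comparison that bears on the change now considered. Compound 3, `Cc1c(CN2CCCC2)cc(-c2ccc(C(F)(F)F)cc2)n1Nc1ccnc2cc(Cl)ccc12`, has not yet been measured; it differs from compound 2 in that (trifluoromethyl in place of fluoro on an aromatic carbon). The measured step ran from a chloro group to a fluoro group and lowered the number by a modest amount; the present change goes the other way, from fluoro to a group of four heavy atoms, so a rise of at least similar size is expected. The step from compound 2 to compound 3 is therefore expected to read about a number 0.75 log units higher from compound 2 to compound 3 (beyond the scatter) in this assay. Compound 3 is estimated at 4.2, within a range from 3.8 to 4.6.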

Compound 3, distribution coefficient: 4.72
Beside the measured number, compound 3's estimate is 0.52 log units below it; measured number above the stated range.
By their numbers in this assay, from the lowest: compound 2; then compound 1; then compound 3.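

Until now this place on the ring, para to a large group, had shown only the move from chloro to fluoro, and that single step could not show how far the number might climb with a different group. In this assay, trifluoromethyl in place of fluoro gives a number 1.27 log units higher from compound 2 to compound 3 (beyond the scatter) and is the largest step seen at this place, while trifluoromethyl in place of chloro gives a number 0.66 log units higher from compound 1 to compound 3 (beyond the scatter) and takes the number past the former top value. The three groups now fall in a clear order here, from fluoro through chloro to trifluoromethyl, with every step beyond the scatter, though no measurement at hand explains the size of any of these steps.

The compounds shown leave open where an amine, a carboxylic acid or a methoxy group would fall in this order at the same place on the ring. They also leave open whether the same order would hold if these groups sat at another place on the ring or on a different core.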